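Methoxy on the Phenyl Ring: From Ketone to Alkene Core

A few compounds are considered here, and "the series" means these few. Any claim that something is new, unique, unknown or untested is made for them only; others in the source may bear on it.

Measured compounds:
compound 1 `COc1ccc([C@@H]2c3c(OC)cc(OC)cc3C(=O)[C@H]2c2cc(OC)cc(OC)c2)cc1` — > 200000 nM
compound 2 `COc1cc(OC)cc([C@@H]2C(=O)c3cc(OC)cc(OC)c3[C@H]2c2ccccc2)c1` — 27100 nM
compound 3 `COc1cc(OC)cc([C@@H]2/C(=C\c3ccccc3)c3cc(OC)cc(OC)c3[C@H]2c2ccccc2)c1` — > 200000 nM

In a functional assay on RAW264.7 cells (Mus musculus) for inhibition, with stated times of 2 h and 24 h (a lower number here means a stronger inhibitor, a higher number a weaker inhibitor), compound 2 gives 27100 nM. Compound 1 reaches only a limit of this assay, > 200000 nM. The change between them is methoxy in place of hydrogen on an aromatic carbon, and the step is an at least 7.3-fold higher number from compound 2 to compound 1 (0.86 log units; beyond the scatter).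

Compound 3 has a different core; the difference between the core of compound 2 and the core of compound 3 is not broken down here. In this assay compound 3 is given only as a limit, > 200000 nM. Two of the three values shown sit at the limit of > 200000 nM in this assay, at which 2 of the 3 values shown sit.

Compound 4 `COc1ccc(/C=C2/c3cc(OC)cc(OC)c3[C@@H](c3ccccc3)[C@@H]2c2cc(OC)cc(OC)c2)cc1` is not yet measured. It differs from compound 3 by methoxy in place of hydrogen on an aromatic carbon, the same change that leads from compound 2 to compound 1. Since compound 3 already stands at the limit and the same change weakened compound 2 by an at least 7.3-fold higher number from compound 2 to compound 1 (0.86 log units; beyond the scatter), compound 4 is expected to remain at or beyond that limit, a step estimated as a step that the limit leaves unreadable from compound 3 to compound 4. Compound 4 is therefore estimated at 300000 nM, with a range from 100000 nM to 1000000 nM.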

Compound 4, half-maximal inhibitory concentration: > 200000 nM
Compound 4: a limit, no number; the forecaster's own chance of this, stated with the estimate: 85%; the middle value does not contradict the limit.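

Compound 3 and compound 4 both stand only at a limit of the assay, so no step can be read between them: the limit of > 200000 nM in this assay, at which 3 of the 4 values shown sit.

The compounds shown leave open whether the change from phenyl to 4-methoxyphenyl has any effect on the core of compound 3, and how far past the limit either compound lies in this assay.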